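The source may hold more compounds than are shown below. What is called first, only, known or untested is meant among the compounds shown, and "the series" means these compounds.

Working notes on the series. Compound 1 `COc1cc(OC)c2c(=O)cc(C(=O)Nc3ccc(Oc4ccc([N+](=O)[O-])cc4)cc3)[nH]c2c1`, compound 2 `COc1cc(OC)c2c(=O)cc(C(=O)Nc3cccc(N4CCCC4)c3)[nH]c2c1` and compound 3 `COc1cc(OC)c2c(=O)cc(C(=O)Nc3cccc(-c4nccs4)c3)[nH]c2c1` share one core and differ in the amide-side substituent. In an ADME assay on BJ cells (Homo sapiens) for antiproliferative activity, with a stated time of 72 h (on this read-out lower numbers stand for an effect already at smaller amounts and higher numbers for an effect only at larger amounts of compound), compound 1 reaches only the limit > 22900 nM. In this assay compound 2 likewise stops at the limit > 58600 nM. In this assay compound 3 stops at the limit > 54000 nM. Compound 3 thus stands, like both others, at a limit and not at a number (the limit of > 22900 nM in this assay, at which 1 of the 3 values shown sits, (the limit of > 54000 nM in this assay, at which 1 of the 3 values shown sits), (the limit of > 58600 nM in this assay, at which 1 of the 3 values shown sits)). Within the data shown here, the only single-change step among measured compounds, a step that the two limits leave unreadable from compound 2 to compound 3, cannot be read in size for the same reason. Compound 4 `COc1cc(OC)c2c(=O)cc(C(=O)Nc3cccc(-n4ccnc4)c3)[nH]c2c1` differs from compound 3 in one place: 1H-imidazol-1-yl in place of 1,3-thiazol-2-yl on an aromatic carbon. Among the measured compounds shown here, no measured step reads on exchanging one five-membered aromatic ring with two hetero atoms for another, since every value shown is a limit. The expectation is that compound 4 also stays at a limit, and the step that the limit leaves unreadable from compound 3 to compound 4 is estimated as none beyond the scatter. For compound 4 the estimated value is 60000 nM, with a range from 20000 nM to 200000 nM.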

Compound 4, half-maximal effective concentration: > 16300 nM
Compound 4 was reported as a limit; the forecaster's own chance of this, stated with the estimate: 85%; the middle value is on the limit's open side.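

In this assay compound 4 gives > 16300 nM, a limit and not a number. No size can be read for the steps from compound 2 or compound 3 to compound 4. The compounds shown leave open whether any amide-side substituent gives a numerical half-maximal effective concentration here.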